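Swapping the sulfonamide cap: thiazole to dimethylpyrimidine

The source may report more compounds than this note shows. Statements on the series, on what has been measured and on what is new or still open speak of the compounds shown alone.

Two thiourea compounds sharing one core have been measured in a functional assay on HepG2 cells (Homo sapiens) for antiproliferative activity, read by sulforhodamine B assay, with a stated time of 48 h; on this read-out lower numbers stand for stronger inhibition and higher numbers for weaker inhibition. Compound 1 `NS(=O)(=O)c1ccc(N/C(S)=N\c2ccnc3cc(C(F)(F)F)ccc23)cc1` carries an unsubstituted sulfonamide and gives 52200 nM. Compound 2 `O=S(=O)(Nc1nccs1)c1ccc(N/C(S)=N\c2ccnc3cc(C(F)(F)F)ccc23)cc1` carries a 1,3-thiazol-2-yl group on the sulfonamide nitrogen and gives 28200 nM. The step of a 1.9-fold lower number from compound 1 to compound 2 (0.27 log units; within the scatter) is the only one seen so far, so compound 2 gives the lowest of the two numbers, though its difference from compound 1 does not exceed the scatter of the measurement.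

Compound 3 `Cc1cc(C)nc(NS(=O)(=O)c2ccc(N/C(S)=N\c3ccnc4cc(C(F)(F)F)ccc34)cc2)n1` has not yet been measured. It differs from compound 2 in one place: 4,6-dimethylpyrimidin-2-yl in place of 1,3-thiazol-2-yl on a sulfonamide nitrogen. For the measured compounds named here, the only step at hand concerns the same sulfonamide nitrogen, where adding the thiazole produced a change that stayed inside the scatter. Replacing one aromatic cap with another at that position therefore gives no ground to expect a step beyond the scatter in this assay, in either direction. Compound 3 is expected to give about 25000 nM, with a likely range from 9000 nM to 70000 nM. The expected step is a 1.1-fold lower number from compound 2 to compound 3 (0.05 log units; within the scatter).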

Compound 3, half-maximal inhibitory concentration: 72200 nM
Beside the measured number, compound 3's estimate is 2.9-fold (0.46 log units) below it; the measured number lies above the stated range.
By their numbers in this assay, from the lowest: compounds 2, 1 and 3 (each within the scatter of the next, the first and the last beyond it).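

For the compounds shown here, at this sulfonamide nitrogen, the choice of aromatic cap does register in this assay: 4,6-dimethylpyrimidin-2-yl in place of 1,3-thiazol-2-yl gives a 2.6-fold higher number from compound 2 to compound 3 (0.41 log units; beyond the scatter) and is the first step here to pass beyond the usual scatter, though only modestly. Neither cap separates clearly from the bare sulfonamide, with a 1.4-fold higher number from compound 1 to compound 3 (0.14 log units; within the scatter) on one side and a 1.9-fold lower number from compound 1 to compound 2 (0.27 log units; within the scatter) on the other, so the effect is visible only as the gap between the two capped compounds, not as a clear change from hydrogen. No measurement available here explains why the pyrimidine cap gives the weaker result of the pair.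

The compounds shown leave open whether the step follows the two methyl groups or the ring itself, a question that a plain pyrimidin-2-yl cap on the same nitrogen would help to answer. They also leave open how this nitrogen responds to a group that is not an aromatic ring, such as a simple methyl or an acetyl.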